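Triazolyl chalcone series: trifluoromethyl step from compound 3

A few compounds are considered here, and "the series" means these few. Any claim that something is new, unique, unknown or untested is made for them only; others in the source may bear on it.

Measured so far:
compound 1 `COc1cc(/C=C/C(=O)c2cccc(-n3cc(-c4ccccc4)nn3)c2)ccc1O` — 16800 nM
compound 2 `COc1cc(/C=C/C(=O)c2cccc(-n3cc(-c4ccc(C)cc4)nn3)c2)ccc1O` — 15400 nM
compound 3 `COc1ccc(/C=C/C(=O)c2cccc(-n3cc(-c4ccccc4)nn3)c2)cc1O` — 1510 nM

In a functional assay on RAW264.7 cells (Mus musculus) for inhibition, with a stated time of 4 days (a lower number here means a stronger inhibitor, a higher number a weaker inhibitor), compound 3 gives the lowest number of the three, and both of its gaps to the others are beyond the scatter: compound 2 sits a 1.1-fold lower number from compound 1 to compound 2 (0.04 log units; within the scatter) relative to compound 1, while the move from compound 1 to compound 3 is an 11-fold lower number from compound 1 to compound 3 (1.05 log units; beyond the scatter). Compound 3 thus stands alone at the strong end on these numbers.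

Compound 4 `COc1ccc(/C=C/C(=O)c2cccc(-n3cc(-c4ccccc4C(F)(F)F)nn3)c2)cc1O` keeps the core of compound 3 and differs from it by trifluoromethyl in place of hydrogen on an aromatic carbon.

Going by the values given here, only one measured step bears on this: the change from compound 1 to compound 2, which likewise adds a small group to the same ring, and which gave a 1.1-fold lower number from compound 1 to compound 2 (0.04 log units; within the scatter). That step sat within the scatter. The group entering here is trifluoromethyl rather than methyl, and it sits at a different place on the ring, so the precedent is loose. With nothing else to go on, the expectation for this assay is no step beyond the scatter, in either direction.

Compound 4 is therefore estimated at 1500 nM, with a range of 600 nM to 4000 nM, which means an expected step of a 1.0-fold lower number from compound 3 to compound 4 (0.00 log units; within the scatter).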

Compound 4, half-maximal inhibitory concentration: 9120 nM
Estimate against measurement, compound 4: 6.1-fold (0.78 log units) below, outside the stated range (above it).
By their numbers in this assay, from the lowest: compound 3; then compounds 4, 2 and 1 (each within the scatter of the next).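

In this assay, the change from phenyl to 2-(trifluoromethyl)phenyl gives a 6.0-fold higher number from compound 3 to compound 4 (0.78 log units; beyond the scatter) and so shows that, with the 3-hydroxy-4-methoxyphenyl group in place, this phenyl does not tolerate every substitution without a penalty. The only earlier substitution on this ring, methyl in place of hydrogen, gave a 1.1-fold lower number from compound 1 to compound 2 (0.04 log units; within the scatter) and stayed within the scatter, but it involved a different group at a different place and with the 4-hydroxy-3-methoxyphenyl group, so the contrast between the two steps cannot be assigned to any one of these differences. Nothing available here gives a measured basis for explaining the weaker number at this position.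

The compounds shown do not settle whether the step follows from trifluoromethyl itself or from a substituent of any kind ortho to a large group. A methyl, a fluorine atom, an amine or a carboxylic acid at that same place, together with trifluoromethyl elsewhere on the ring, would separate the identity of the group from its position.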